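Series notes: the step from compound 2 to compound 4

The compounds below may be only part of what the source reports. "The series", "measured", "known", "first", "only" and "open" are said of these compounds alone.

In an ADME assay on cells (Peritoneal macrophage cell, Mus musculus) for cytotoxicity, read by fluorescence and resazurin assay, with a stated time of 3 days (a lower number here means that less compound is tolerated, a higher number that more compound is tolerated), compound 1 (`COc1ccc(C(=O)Nc2cc(-c3ccccn3)n[nH]2)cc1`) reads only as a limit (> 40300 nM). Compound 2 (`COc1ccc(C(=O)Nc2[nH]nc(-c3ccccn3)c2C2CC2)cc1`) also reads only as a limit (> 64000 nM). Compound 3 (`N#Cc1ccc(C2CCN(C(=O)Nc3cc(-c4ccccn4)n[nH]3)CC2)cc1`) reads only as a limit too (> 64000 nM). Compound 2 therefore has no number to start from. Compound 4 (`O=C(Nc1[nH]nc(-c2ccccn2)c1C1CC1)c1c(Cl)cccc1Cl`) changes the group on the carbonyl carbon (2,6-dichlorophenyl in place of 4-methoxyphenyl on a carbonyl carbon). Among the compounds with values here, the only measured step (a step that the two limits leave unreadable from compound 1 to compound 2) concerns a cyclopropyl in place of hydrogen on an aromatic carbon, and it gives no size to carry over. No shift beyond the scatter is therefore expected in this assay, in either direction. The expected step is (an at least 1.2-fold lower number from compound 2 to compound 4 (0.10 log units; that floor lies within the scatter)). For compound 4 the estimate is 50000 nM (expected range 18000 nM to 64000 nM).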

Compound 4, half-maximal cytotoxic concentration: > 64000 nM
Compound 4: no number, only a limit; the forecaster's own chance of this, stated with the estimate: 60%; middle value at least 1.2-fold (0.10 log units) from the limit.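

Within the data shown here, compound 2 and compound 4 both stand only as limits in this assay, and no step between them can be read. The compounds shown leave open whether 2,6-dichlorophenyl in place of 4-methoxyphenyl shifts the half-maximal cytotoxic concentration at all.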